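The source may hold more compounds than are shown below. What is called first, only, known or untested is meant among the compounds shown, and "the series" means these compounds.

Working notes on the series. Compound 1 `CCN1CCN(Cc2c(OC)cc(Oc3cccc(Nc4ccccc4)c3)cc2OC)CC1` carries the 4-ethylpiperazin-1-yl group on a saturated chain carbon bound to an aromatic carbon. In a functional assay on HCT-116 cells (Homo sapiens) for inhibition, read by MTT assay, with a stated time of 72 h (a lower number here means a stronger inhibitor, a higher number a weaker inhibitor), compound 1 gives > 20000 nM, which is a limit of the assay and not a number, so only a floor is known for it (the limit of > 20000 nM in this assay, at which 1 of the 3 values shown sits). Compound 2 `COc1cc(Oc2cccc(Nc3ccccc3)c2)cc(OC)c1CNCc1ccc(Cl)cc1` gives 3310 nM in this assay. Compound 3 `COc1cc(Oc2cccc(Nc3ccccc3)c2)cc(OC)c1CNCCNC(C)=O` gives 18200 nM in this assay. Among the compounds with values here, replacing the 4-ethylpiperazin-1-yl group reads an at least 6.0-fold lower number from compound 1 to compound 2 (0.78 log units; beyond the scatter) and an at least 1.0-fold lower number from compound 1 to compound 3 (0.04 log units; that floor lies within the scatter); between the two replacements the difference reads a 5.5-fold higher number from compound 2 to compound 3 (0.74 log units; beyond the scatter), so the (4-chlorobenzyl)amino group is the one that moves the number, while the (2-acetamidoethyl)amino group does not.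

Compound 4 `COc1ccc(CNCc2c(OC)cc(Oc3cccc(Nc4ccccc4)c3)cc2OC)cc1` is not yet measured. Against compound 1 the change is (4-methoxybenzyl)amino in place of 4-ethylpiperazin-1-yl on a saturated chain carbon bound to an aromatic carbon. The closest measured step is an at least 6.0-fold lower number from compound 1 to compound 2 (0.78 log units; beyond the scatter), where the entering group is likewise a substituted benzyl on the amine nitrogen; the step of an at least 1.0-fold lower number from compound 1 to compound 3 (0.04 log units; that floor lies within the scatter) shows that the amine alone, without the aromatic ring, gives nothing beyond the scatter. A lowering of about the size seen for compound 2 is therefore expected, as an at least 4.4-fold lower number from compound 1 to compound 4 (0.64 log units; beyond the scatter). Compound 4 is expected to give 4500 nM, with a range from 1500 nM to 14000 nM.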

Compound 4, half-maximal inhibitory concentration: 2620 nM
Compound 4: the middle estimate sits 1.7-fold (0.23 log units) above what was measured; low and high end bracket the measured number.
By their numbers in this assay, from the lowest: compounds 4 and 2 (each within the scatter of the next); then compound 3. At a limit, above all of these: compound 1.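

Compound 1 stands at a limit of the assay and not at a number, so any step from it is only a floor: the limit of > 20000 nM in this assay, at which 1 of the 4 values shown sits.

Within that reservation, this assay reads an at least 7.6-fold lower number from compound 1 to compound 4 (0.88 log units; beyond the scatter) and a 6.9-fold lower number from compound 3 to compound 4 (0.84 log units; beyond the scatter), so a second substituted benzyl on the amine nitrogen at this place, on a saturated chain carbon bound to an aromatic carbon, repeats the separation from compound 1 and compound 3 that compound 2 alone had shown. Methoxy in place of chloro on an aromatic carbon reads a 1.3-fold lower number from compound 2 to compound 4 (0.10 log units; within the scatter), so the two substituents cannot be told apart here, and what sets compound 2 and compound 4 apart from compound 3 is the substituted benzyl and not the choice of substituent on it.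

The compounds shown leave open what an unsubstituted benzyl, or a hydroxyl or trifluoromethyl on the same ring, would read, and whether a phenethyl on the amine nitrogen would keep the number. They also leave open whether the aromatic ring suffices without the amine hydrogen, which a 4-benzylpiperazin-1-yl group in place of the 4-ethylpiperazin-1-yl group would test.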